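Bromo for chloro on two related cores

The source may report more compounds than this note shows. Statements on the series, on what has been measured and on what is new or still open speak of the compounds shown alone.

Measured compounds:
compound 1, `CN1CCC[C@H]1COc1cncc(Cl)c1`, gives 0.6 nM in an assay on membranes from brain for displacement of a labelled ligand from Neuronal acetylcholine receptor; alpha4/beta2 (Rattus norvegicus); a lower number here means a stronger inhibitor, a higher number a weaker inhibitor
compound 2, `CN1CCC[C@H]1COc1cncc(Br)c1`, gives 0.27 nM in this assay
compound 3, `CN1CCC[C@H]1COc1ccc(Cl)nc1`, gives 0.64 nM in this assay

Compound 1 and compound 3 share the same atoms joined differently; the difference between the two cores is not broken down here. On the core of compound 1, the change bromo in place of chloro on an aromatic carbon gives a 2.2-fold lower number from compound 1 to compound 2 (0.35 log units; beyond the scatter). Compound 3 stands within the scatter of compound 1 and beyond it only against compound 2.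

Compound 4, `CN1CCC[C@H]1COc1ccc(Br)nc1`, is not yet measured. It carries the change (bromo in place of chloro on an aromatic carbon). This is the same kind of change as that from compound 1 to compound 2, not the same: there the place was two atoms from the ring nitrogen and meta to a group of 8 heavy atoms, here it is next to the ring nitrogen and para to a group of 8 heavy atoms. The step from compound 3 to compound 4 is expected to be a 2.1-fold lower number from compound 3 to compound 4 (0.33 log units; beyond the scatter) in this assay, because the earlier case gave a 2.2-fold lower number from compound 1 to compound 2 (0.35 log units; beyond the scatter). Compound 4 is therefore expected to give 0.3 nM, estimated between 0.15 nM and 0.7 nM.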

Compound 4, inhibition constant: 1.91 nM
Compound 4: the middle estimate sits 6.4-fold (0.80 log units) below what was measured, outside the stated range (above it).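

In this assay, bromo in place of chloro on an aromatic carbon does not carry over from the core of compound 1 to the core of compound 3: with the halogen next to the ring nitrogen and para to a group of 8 heavy atoms, the direction reverses, giving a 3.0-fold higher number from compound 3 to compound 4 (0.47 log units; beyond the scatter). Set side by side, the two steps differ in direction and by more than their scatter: the same change on two cores in this assay, a 2.2-fold lower number (0.35 log units; beyond the scatter) from compound 1 to compound 2 and a 3.0-fold higher number (0.47 log units; beyond the scatter) from compound 3 to compound 4, 6.6-fold (0.82 log units) apart, beyond the scatter of two such steps
So in this series, the step seen on one core is no guide to the same change on the other, although the data do not show which feature of the two cores sets the steps apart, and one pair per core gives no rule for any further core.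

As far as these compounds go, whether a fluoro, a nitrile or an amine on that aromatic carbon would follow the trend of the core of compound 1 or that of compound 3 stays open. Also open, from the compounds shown here alone, is whether iodo would extend either step.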